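The source may hold more compounds than are shown below. What is called first, only, known or untested is meant among the compounds shown, and "the series" means these compounds.

Compound 1: `CCn1c(CNc2ccccc2)nnc1SCC(=O)Nc1ccc(OC)cc1`
Compound 2: `CCn1c(CNc2ccccc2)nnc1SCC(=O)Nc1ccc(C(=O)OC)cc1`
Compound 3: `CCn1c(CNc2ccccc2)nnc1SCC(=O)Nc1ccccc1`

In an assay on isolated protein for inhibition of long-chain fatty acid transport protein 1 (Homo sapiens) (a higher number here means a weaker inhibitor, a lower number a stronger inhibitor), compound 1 gives > 1000 nM, which is a limit of the assay rather than a number. Compound 2 gives 540 nM. Compound 3 gives > 1000 nM, again a limit and not a number. Compound 3 thus stands at the edge of what the assay can resolve, and the step that the two limits leave unreadable from compound 1 to compound 3 cannot be read because of the limit of > 1000 nM in this assay, at which 2 of the 3 values shown sit. The two steps that touch the methoxycarbonyl group, an at least 1.8-fold lower number from compound 1 to compound 2 (0.26 log units; that floor lies within the scatter) and an at least 1.8-fold higher number from compound 2 to compound 3 (0.26 log units; that floor lies within the scatter), are both only floors and both lie within the usual scatter.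

Compound 4, `CCOC(=O)c1ccc(NC(=O)CSc2nnc(CNc3ccccc3)n2CC)cc1`, has not yet been measured. It differs from compound 3 by ethoxycarbonyl in place of hydrogen on an aromatic carbon. The step that bears on it most directly is an at least 1.8-fold higher number from compound 2 to compound 3 (0.26 log units; that floor lies within the scatter), here run in the opposite direction, with a larger ester group entering. On that basis a lower number is expected, by at least the floor seen there, though a step that clears the scatter is not assured. Compound 4 is expected to give 500 nM, within a range from 200 nM to 1500 nM. The expected step from its parent is an at least 2.0-fold lower number from compound 3 to compound 4 (0.30 log units; that floor lies within the scatter).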

Compound 4, half-maximal inhibitory concentration: 330 nM
Estimate against measurement, compound 4: 1.5-fold (0.18 log units) above, and the stated range covers the measured number.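

In this assay, ethoxycarbonyl on the aromatic carbon para to a large group gives a step that clears the scatter, which neither step involving the methoxycarbonyl compound did: an at least 3.0-fold lower number from compound 3 to compound 4 (0.48 log units; beyond the scatter), and the swap of methoxy for the same group gives an at least 3.0-fold lower number from compound 1 to compound 4 (0.48 log units; beyond the scatter). Both sizes are floors and not exact measures, because compound 1 and compound 3 each carry a limit of the assay rather than a number: the limit of > 1000 nM in this assay, at which 2 of the 4 values shown sit. The added methyl that turns methoxycarbonyl into ethoxycarbonyl gives a 1.6-fold lower number from compound 2 to compound 4 (0.21 log units; within the scatter), which lies within the scatter, so this extension of the ester cannot be told apart from no change.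

The compounds shown leave open whether the ester itself matters at this position, since a carboxylic acid, an amide or a nitrile in the same place would be needed to test that. They also leave open whether a longer chain on the ester, such as propoxycarbonyl or butoxycarbonyl, would produce a step beyond the scatter.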